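The source may report more compounds than this note shows. Statements on the series, on what has been measured and on what is new or still open speak of the compounds shown alone.

Measured so far in an assay on MDA-MB-231 cells for binding affinity to C-X-C chemokine receptor type 4 (Homo sapiens), read by immunofluorescence and microscopy, with stated times of 10 min and 30 min; on this read-out higher numbers stand for an effect only at larger amounts of compound and lower numbers for an effect already at smaller amounts:
compound 1, `Cc1ccc(S(=O)(=O)NCc2ccc(CNC(=O)c3ccc(Cl)cc3)cc2)cc1`, gives 10 nM.
compound 2, `Cc1ccc(S(=O)(=O)NCc2ccc(CNC(=O)c3ccccc3C)cc2)cc1`, gives 100 nM.

Among the measured compounds shown here, compound 2 stands at the highest of the two numbers; its only neighbour is compound 1, and the single measured step, a 10-fold higher number from compound 1 to compound 2 (1.00 log units; beyond the scatter), lies beyond the scatter. Compound 3, `Cc1ccc(S(=O)(=O)NCc2ccc(CNC(=O)c3cccnc3)cc2)cc1`, has not yet been measured. Its change from compound 2 is pyridin-3-yl in place of 2-methylphenyl on a carbonyl carbon. For the measured compounds named here, only one measured step touches the group on the carbonyl carbon, namely a 10-fold higher number from compound 1 to compound 2 (1.00 log units; beyond the scatter), and it shows that an exchange at that place can shift the number by a modest amount. Going by the values given here, no measured compound carries a pyridin-3-yl there, and no measured pair swaps a ring of carbon only for a ring with one hetero atom, so the direction for compound 3 cannot be read from the numbers in hand; the step is known only to be possible at this size. The step expected is therefore a 1.7-fold lower number from compound 2 to compound 3 (0.22 log units; within the scatter), with wide uncertainty. For compound 3 the estimated value in this assay is 60 nM, with a range from 15 nM to 300 nM.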

Compound 3, effective concentration (reported as EC, without a stated level of effect): > 1000 nM
Compound 3 gave a limit, no number (the forecaster's own chance of this, stated with the estimate: 5%); middle value at least 16-fold (1.22 log units) away from the limit.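

In this assay, compound 3 is recorded only as a limit of the assay, not as a number: the limit of > 1000 nM in this assay, at which 1 of the 3 values shown sits.

Pyridin-3-yl on the carbonyl carbon, the first ring here with a hetero atom at this place, gives an at least 10-fold higher number from compound 2 to compound 3 (1.00 log units; beyond the scatter) and an at least 100-fold higher number from compound 1 to compound 3 (2.00 log units; beyond the scatter). Among the compounds shown here, the earlier pair showed only that an exchange at this place can move the number, whereas these three compounds now fall in an order: 4-chlorophenyl gives the lowest number, 2-methylphenyl the next, and pyridin-3-yl the highest, with both rings of carbon only ahead of the ring with one hetero atom, a pattern claimed for these three compounds alone.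

The compounds shown leave open how much of the step from 2-methylphenyl to pyridin-3-yl goes with the ring nitrogen and how much with the missing methyl, a question that plain phenyl on the carbonyl carbon would address. They also leave open whether chlorine on a pyridine ring would bring the number back towards that of the 4-chlorophenyl compound, or whether the ring nitrogen is not tolerated at this place whatever else the ring carries.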